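This account rests on a few compounds, and the source may have more. Where it says the series, first, only, none or still open, it means among the compounds named here.

Measured so far:

- compound 1, `O=C(N/N=C/c1cccc(O)c1)c1cccnc1Nc1cccc(C(F)(F)F)c1`: 67.5%
- compound 2, `CNc1ncccc1C(=O)N/N=C/c1ccccc1`: 56.5%

Of the compounds shown here, two have been measured. In a functional assay on the whole organism (strain Wistar) for inhibition, with Rattus norvegicus as the target, read by paw edema, with a stated time of 30 min, at a dose of 10 mg/kg by the intraperitoneal route (a lower number here means less inhibition, a higher number more inhibition at the dose given (going by the name of the read-out)), compound 1 gives 67.5%, and compound 2 gives 56.5%. Compound 2 therefore stands lowest of the two numbers; its nearest neighbour is compound 1, whose number lies higher by a gap beyond the usual scatter of this kind of measurement. Among the measured compounds shown here, the two share no single-point relation, so their values show only that compound 1 sits above compound 2 in this assay.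

Compound 3, `CNc1ncccc1C(=O)N/N=C/c1cccc(Cl)c1`, has not yet been measured in this assay. Its structure differs from that of compound 2 in one place: chloro in place of hydrogen on an aromatic carbon. For the measured compounds named here, no pair of measured compounds isolates this same change, so there is no measured step to lean on. On the strength of the two numbers alone, the step in this assay from compound 2 to compound 3 is expected to be small, either direction, and probably within the scatter. Compound 3 is accordingly estimated at 58%, with a plausible range of 45% to 72%, which means an expected step of a number 1.5 percentage points higher from compound 2 to compound 3 (within the scatter).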

Compound 3, a percentage reported as inhibition, in the whole organism at one dose (the size of the read-out at that dose, not a potency): 67.1%
Beside the measured number, compound 3's estimate is 9.1 percentage points below it; the measured number falls inside the stated range.
By their numbers in this assay, from the lowest: compound 2; then compounds 3 and 1 (each within the scatter of the next).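

In this assay, among the compounds shown here, chloro in place of hydrogen on an aromatic carbon, meta to a large group, gives a number 10.6 percentage points higher from compound 2 to compound 3 (beyond the scatter) and this is the first measured step that isolates a single change. It shows that this place on the six-membered aromatic ring is not indifferent to substitution at the dose given: one chlorine atom, bringing no ring, no hydrogen-bond donor or acceptor and no net charge, is enough to move the number by a modest but readable amount. No supporting data bear on why the step has this direction or size.

Whether this gain belongs to chloro itself remains open, as the compounds shown do not tell whether a fluoro, a methyl, a methoxy or an amine on the same carbon would move the number in the same way or by a similar amount. They also leave open whether chloro at another carbon of that ring would give a comparable step, and whether the methylamino group of compound 3 could be exchanged for a longer chain without losing it.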